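Replacing furan-3-yl with ethynyl in compound 2

The source may report more compounds than this note shows. Statements on the series, on what has been measured and on what is new or still open speak of the compounds shown alone.

Values in a functional assay on HL-60 cells (Homo sapiens) for antiproliferative activity, read by XTT assay, with a stated time of 72 h (on this read-out higher numbers stand for weaker inhibition and lower numbers for stronger inhibition), for the measured compounds
Compound 1 `COc1ncnc2c1c(-c1ccccc1)cn2[C@@H]1O[C@H](CO)[C@@H](O)[C@H]1O` at > 20000 nM (a limit of the assay, not a number)
Compound 2 `CSc1ncnc2c1c(-c1ccoc1)cn2[C@@H]1O[C@H](CO)[C@@H](O)[C@H]1O` at 360 nM
Compound 3 `CSc1ncnc2c1c(-c1ccsc1)cn2[C@@H]1O[C@H](CO)[C@@H](O)[C@H]1O` at 4590 nM

Going by the values given here, compound 1 stays a limit, so only two actual numbers can be compared. Of those two, compound 2 holds the lower one, and the other lies well away from it. Among the compounds with values here, the only measured step that bears on this place is a 13-fold higher number from compound 2 to compound 3 (1.11 log units; beyond the scatter) (thiophen-3-yl in place of furan-3-yl on an aromatic carbon). That step is large, even though one five-membered aromatic ring simply replaces another.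

Compound 4 `C#Cc1cn([C@@H]2O[C@H](CO)[C@@H](O)[C@H]2O)c2ncnc(SC)c12` has not yet been measured and differs from compound 2 at that same carbon (ethynyl in place of furan-3-yl on an aromatic carbon), with ethynyl in place of furan-3-yl. Here the ring is lost altogether, and a triple bond outside aromatic rings enters. Within the data shown here, with a 13-fold higher number from compound 2 to compound 3 (1.11 log units; beyond the scatter) as the only guide, a higher number than that of compound 2 is expected, by a step of similar or smaller size. This direction rests on a single comparison, so the expectation stays wide. In this assay the expected step is a 4.2-fold higher number from compound 2 to compound 4 (0.62 log units; beyond the scatter) (an estimate). For compound 4 the estimated value is 1500 nM (expected range 250 nM to 9000 nM).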

Compound 4, half-maximal inhibitory concentration: 50 nM
Compound 4: middle estimate off by 30-fold (1.48 log units), on the high side; measured number below the stated range.
By their numbers in this assay, from the lowest: compound 4; then compound 2; then compound 3. At a limit, above all of these: compound 1.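

In this assay, a five-membered aromatic ring proves unnecessary at this carbon, since ethynyl in place of furan-3-yl lowers the number (a 7.2-fold lower number from compound 2 to compound 4 (0.86 log units; beyond the scatter)). Going by these compounds alone, the earlier pair showed only that exchanging one ring for another could shift the number a long way, whereas here the ring is lost altogether, and a group of 2 heavy atoms with a triple bond gives a lower number than either ring-bearing compound with the same methylthio core, with the widest step coming from the thiophen-3-yl compound (a 92-fold lower number from compound 3 to compound 4 (1.96 log units; beyond the scatter)). No measurement shown here explains why ethynyl stands apart from the two rings at this carbon.

The compounds shown leave open whether the triple bond matters in itself, or whether an ethyl chain, a vinyl group or a nitrile on this carbon would give a similar number. They also leave open how ethynyl behaves with the methoxy group of compound 1, which carries phenyl at this carbon and stands at > 20000 nM, a limit of the assay and not a number.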